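The source may hold more compounds than are shown below. What is called first, only, known or untested is meant among the compounds shown, and "the series" means these compounds.

Measured compounds:

compound 1 `Nc1cc(N)c2nc(-c3ccccc3)c(Sc3ccc(F)cc3)nc2c1`: < 100000 nM
compound 2 `COc1cc(CNc2nc3cc(N)cc(N)c3nc2-c2ccccc2)cc(OC)c1OC`: < 50200 nM
compound 3 `CCOC(=O)[C@H](CCC(=O)O)NC(=O)c1ccc(Oc2nc3cc(N)cc(N)c3nc2-c2ccccc2)cc1`: < 100000 nM

In a functional assay on MCF7 cells (Homo sapiens) for inhibition, read by sulforhodamine B assay, with a stated time of 48 h (on this read-out lower numbers stand for higher toxicity in this test and higher numbers for lower toxicity in this test), none of the three compounds gives a true number. Compound 1 sits at the limit of < 100000 nM in this assay, at which 2 of the 3 values shown sit, which is a limit of the assay and not a measured value. Compound 2 sits at the limit of < 50200 nM in this assay, at which 1 of the 3 values shown sits, again only a limit. Compound 3 likewise reaches only a limit. So where compound 1 stands cannot be told more precisely than that its toxicity lies somewhere past the ceiling of what the test could report, and the same holds for the other two.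

The untested compound 4 `Nc1cc(N)c2nc(-c3ccccc3)c(NCc3ccc(F)cc3)nc2c1` is compound 1 with one change: (4-fluorobenzyl)amino in place of (4-fluorophenyl)sulfanyl on an aromatic carbon. For the measured compounds named here, no measured pair in this set differs in one place, so no step of known size is available to lean on. With all three shared-core compounds returning only limits in this assay, the plain expectation is a step of no size beyond the scatter. The estimate for compound 4 is 60000 nM, in the range 15000 nM to 200000 nM. The expected step is therefore a step that the limit leaves unreadable from compound 1 to compound 4, that is, essentially none.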

Compound 4, concentration lethal to 50% of the cells: < 100000 nM
Compound 4: only a limit was reported; the forecaster's own chance of this, stated with the estimate: 65%; the middle value is on the limit's open side.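

For the compounds shown here, compound 1 and compound 4 both return only a limit in this assay, and no step between them can be read. The compounds shown leave open how toxic each one truly is, and whether (4-fluorobenzyl)amino in place of (4-fluorophenyl)sulfanyl changes that at all.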